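A few compounds are considered here, and "the series" means these few. Any claim that something is new, unique, unknown or untested is made for them only; others in the source may bear on it.

The measured compounds:
Compound 1, `COc1ccc(Nc2nc(/C=C/c3cc(OC)c(OC)c(OC)c3)nc3ccsc23)cc1`. In an ADME assay on RAW264.7 cells (Mus musculus) for cytotoxicity, read by MTT assay (on this read-out higher numbers stand for weaker inhibition and lower numbers for stronger inhibition), compound 1 gives > 50000 nM, which is a limit of the assay.
Compound 2, `COc1cc(/C=C/c2nc(Nc3ccc(C(F)(F)F)cc3)c3sccc3n2)cc(OC)c1OC`. In this assay compound 2 gives > 50000 nM, again a limit.
Compound 3, `COc1cc(/C=C/c2nc(NCc3ccccc3)c3sccc3n2)cc(OC)c1OC`. In this assay compound 3 gives > 50000 nM, also a limit.

Compound 3 therefore stands where every measured compound stands, at the limit of > 50000 nM in this assay, at which 3 of the 3 values shown sit. Going by the values given here, the three pairwise steps among the measured compounds, a step that the two limits leave unreadable from compound 1 to compound 2, a step that the two limits leave unreadable from compound 1 to compound 3 and a step that the two limits leave unreadable from compound 2 to compound 3, are all left unreadable by the limits, so no step among them carries a size.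

Compound 4, `COc1cc(/C=C/c2nc(NCc3ccc(C)cc3)c3sccc3n2)cc(OC)c1OC`, differs from compound 3 by methyl in place of hydrogen on an aromatic carbon. Among the compounds with values here, no measured step concerns such a change, and none of the measured steps has a readable size to lean on. Compound 3 itself sits at the limit, so the expected step of a number no higher from compound 3 to compound 4 (the limit leaves the size open) from compound 3 to compound 4 is none beyond the scatter, with the result most likely again reported as a limit. Compound 4 is thus estimated at 50000 nM in this assay, with an expected range from 20000 nM to 100000 nM.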

Compound 4, half-maximal inhibitory concentration: > 50000 nM
Compound 4: only a limit was reported (the forecaster's own chance of this, stated with the estimate: 85%); the middle value sits exactly at the limit.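

Going by these compounds alone, compound 4 sits with compound 1, compound 2 and compound 3 in this assay, so no step to compound 4 from any of them can be read: the limit of > 50000 nM in this assay, at which 4 of the 4 values shown sit. The compounds shown leave open whether any of these changes shifts the half-maximal inhibitory concentration at all.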